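Replacing the benzylic link by a direct pyrimidine

The source may hold more compounds than are shown below. What is called first, only, known or untested is meant among the compounds shown, and "the series" means these compounds.

Three compounds share one core and were measured in an assay on CHO cells for displacement of a labelled ligand from 5-hydroxytryptamine receptor 1B (Homo sapiens); on this read-out higher numbers stand for weaker inhibition and lower numbers for stronger inhibition:
compound 1 `c1cc(CN2CCN(CCCc3c[nH]c4ccc(-n5cnnc5)cc34)CC2)ccn1` gives 23 nM
compound 2 `c1coc(CN2CCN(CCCc3c[nH]c4ccc(-n5cnnc5)cc34)CC2)c1` gives 18 nM
compound 3 `CC(=O)Nc1ccc(CN2CCN(CCCc3c[nH]c4ccc(-n5cnnc5)cc34)CC2)cc1` gives 56 nM

Compound 1 stands second highest of the three numbers; its nearest neighbour is compound 2, with a 1.3-fold lower number from compound 1 to compound 2 (0.11 log units; within the scatter), a step within the scatter, and its furthest is compound 3, with a 2.4-fold higher number from compound 1 to compound 3 (0.39 log units; beyond the scatter). Compound 4 `c1cnc(N2CCN(CCCc3c[nH]c4ccc(-n5cnnc5)cc34)CC2)nc1` has not been measured. It differs from compound 1 by pyrimidin-2-yl in place of (pyridin-4-yl)methyl on an amine nitrogen in a ring. Within the data shown here, none of the measured steps covers this change: each of them swaps the aromatic group while keeping the saturated chain carbon in place, and the largest of them, a 3.1-fold higher number from compound 2 to compound 3 (0.49 log units; beyond the scatter), is only modest. The step to compound 4 removes that chain carbon and attaches the ring directly, so the measured steps give only a weak guide. On this basis the expected step in this assay is small, with wide uncertainty, and the estimate for compound 4 is 40 nM, within 10 nM to 160 nM, meaning an expected 1.7-fold higher number from compound 1 to compound 4 (0.24 log units; within the scatter).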

Compound 4, half-maximal inhibitory concentration: 0.5 nM
For compound 4 the middle estimate is 80-fold (1.90 log units) above the measured one; measured number below the stated range.
By their numbers in this assay, from the lowest: compound 4; then compounds 2 and 1 (each within the scatter of the next); then compound 3.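

In this assay, the substituent on the amine nitrogen in the ring proved far more sensitive to this change than the earlier swaps of the aromatic group had shown, with large steps from all three earlier compounds (a 46-fold lower number from compound 1 to compound 4 (1.66 log units; beyond the scatter); a 36-fold lower number from compound 2 to compound 4 (1.56 log units; beyond the scatter); a 110-fold lower number from compound 3 to compound 4 (2.05 log units; beyond the scatter)). Those earlier swaps all kept the saturated chain carbon and stayed within the scatter or modest, so among these four compounds, the change that removes that carbon and attaches pyrimidin-2-yl directly counts for more than any exchange of aromatic group. Nothing measured here accounts for the gain.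

The single step changes both the link and the ring, so the compounds shown do not separate the two contributions. A (pyrimidin-2-yl)methyl group, or a phenyl or pyridin-4-yl ring bound directly to the amine nitrogen, would pull them apart.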